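The source may report more compounds than this note shows. Statements on the series, on what has been measured and on what is new or still open speak of the compounds shown alone.

Compound 1 `FC(F)(F)c1ccc(-c2nn(-c3ccccc3)cc2CNc2ccc(Cl)cc2)cc1`: 10000 nM
Compound 2 `Cc1ccc(NCc2cn(-c3ccccc3)nc2-c2ccccc2)cc1`: > 100000 nM
Compound 3 `Cc1ccc(-c2nn(-c3ccccc3)cc2CNc2ccc(Br)cc2)cc1`: 92000 nM

These values come from an ADME assay on Vero 76 cells (Chlorocebus sabaeus) for cytotoxicity, read by MTT assay, with a stated time of 96 h; on this read-out higher numbers stand for lower toxicity in this test and lower numbers for higher toxicity in this test. Compound 3, at 92000 nM, holds the higher of the two true numbers, and compound 1, at 10000 nM, lies lower by more than the usual scatter. The entry for compound 2, > 100000 nM, is a limit of the assay and not a number.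

Compound 4 `Cc1ccc(-c2nn(-c3ccccc3)cc2CNc2ccc(C(F)(F)F)cc2)cc1` differs from compound 3 in one place: trifluoromethyl in place of bromo on an aromatic carbon. The trifluoromethyl group replaces bromo on an aromatic carbon, para to a large group. Among the compounds with values here, no measured pair isolates this change, so the evidence is thin. Within the data shown here, compound 1, the only measured compound bearing trifluoromethyl, gives 10000 nM, but it differs from compound 3 in more than one place. A moderate fall in this assay is therefore expected, a 2.3-fold lower number from compound 3 to compound 4 (0.36 log units; beyond the scatter). The estimated value for compound 4 is 40000 nM, with an expected range of 10000 nM to 100000 nM.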

Compound 4, half-maximal cytotoxic concentration: 45000 nM
Estimate against measurement, compound 4: 1.1-fold (0.05 log units) below; the range from low to high includes it.
By their numbers in this assay, from the lowest: compound 1; then compound 4; then compound 3. At a limit, above all of these: compound 2.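

Within the data shown here, this is the first pair that isolates a single change at this position, on the six-membered aromatic ring of carbon only. In this assay, the change from bromo to trifluoromethyl gives a 2.0-fold lower number from compound 3 to compound 4 (0.31 log units; beyond the scatter), so a modest but real shift follows from this one swap. No measurement shown explains why the number falls.

On these data alone, whether an amine or a carboxylic acid at this position would shift the number further remains open. So does whether the same swap would give a similar step in a compound with a different group elsewhere.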